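Adding phenyl to a compound stuck at a limit

The compounds below may be only part of what the source reports. "The series", "measured", "known", "first", "only" and "open" are said of these compounds alone.

Compound 1 `CCN(CC)CC#CCCC1SCCCS1`: > 10000000 nM
Compound 2 `CN(C)CC#CCCC1SCCCS1`: > 10000000 nM

In a functional assay for antagonist activity, with Cavia porcellus as the target (a higher number here means a weaker inhibitor, a lower number a stronger inhibitor), compound 1 gives > 10000000 nM, which is a limit and not a number. Compound 2 gives > 10000000 nM, also a limit. Among the measured compounds shown here, the evidence so far is only (the limit of > 10000000 nM in this assay, at which 2 of the 2 values shown sit), and the one measured step, a step that the two limits leave unreadable from compound 1 to compound 2, has no readable size and concerns a different part of the molecule. Compound 3 `CCN(CC)CC#CCCC1(c2ccccc2)SCCCS1` differs from compound 1 as follows: phenyl in place of hydrogen on a saturated ring carbon. For the measured compounds named here, no measured step bears on this change, so any expectation is loose. With compound 1 at > 10000000 nM, only a move towards stronger inhibition could be read. An estimated step is expected, an at least 330-fold lower number from compound 1 to compound 3 (2.52 log units; beyond the scatter). Compound 3 is estimated at 30000 nM, with an expected range of 1000 nM to 10000000 nM.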

Compound 3, antagonist equilibrium constant: 900 nM
For compound 3 the middle estimate is 33-fold (1.52 log units) above the measured one, outside the stated range (below it).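

In this assay, phenyl in place of hydrogen on a saturated ring carbon produces an at least 11000-fold lower number from compound 1 to compound 3 (4.04 log units; beyond the scatter). Compound 3 is thus the only compound shown with a readable value, which makes this ring carbon, between two ring sulfur atoms, the one place where a change is seen to matter. The true size of the step stays unknown, since it is measured from a limit: the limit of > 10000000 nM in this assay, at which 2 of the 3 values shown sit.

From the compounds shown here alone, whether methyl or cyclohexyl at this carbon would also give a readable value remains open. So does whether dimethylamino in place of diethylamino changes anything once phenyl is present.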